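Benzothiazole for Cyanophenyl: Expected Outcome for Compound 4

A few compounds are considered here, and "the series" means these few. Any claim that something is new, unique, unknown or untested is made for them only; others in the source may bear on it.

Compound 1 `COc1c(OCCCCN2CCN(C)CC2)cc(O)c2c(=O)cc(-c3ccc(Cl)cc3)oc12` gives 1430 nM in a functional assay on A549 cells (Homo sapiens) for cytotoxicity, read by MTT assay, with a stated time of 72 h; a lower number here means a stronger inhibitor, a higher number a weaker inhibitor.
Compound 2 `COc1c(OCCCCN2CCN(C)CC2)cc(O)c2c(=O)cc(-c3ccc(C(F)(F)F)cc3)oc12` gives 2890 nM in this assay.
Compound 3 `CN1CCN(CCCCOc2c(OCc3ccc(C#N)cc3)cc(O)c3c(=O)cc(-c4ccccc4)oc23)CC1` gives 2140 nM in this assay.

Among these three numbers, compound 3 falls in the span set by compound 1 and compound 2, and its distance to either of them lies within the usual scatter of repeated measurements, so no order among the three can be read from compound 3's number. Going by the values given here, the only step measured beyond the scatter is a 2.0-fold higher number from compound 1 to compound 2 (0.31 log units; beyond the scatter), which concerns the aryl group on the core, not the side chain.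

Compound 4 `CN1CCN(CCCCOc2c(OCc3nc4ccccc4s3)cc(O)c3c(=O)cc(-c4ccccc4)oc23)CC1` differs from compound 3 by 1,3-benzothiazol-2-yl in place of 4-cyanophenyl on a saturated chain carbon bound to an oxygen on an aromatic ring. Among the compounds with values here, no measured step touches this position, so nothing in the data points to a change in either direction, and a step within the scatter is the expectation. Compound 4 is therefore estimated at 2000 nM in this assay, with a range from 800 nM to 5000 nM, which amounts to an expected step of a 1.1-fold lower number from compound 3 to compound 4 (0.03 log units; within the scatter).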

Compound 4, half-maximal inhibitory concentration: 1060 nM
Compound 4: the middle estimate sits 1.9-fold (0.28 log units) above what was measured, within the range that was stated.
By their numbers in this assay, from the lowest: compounds 4, 1, 3 and 2 (each within the scatter of the next, the first and the last beyond it).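

Putting 1,3-benzothiazol-2-yl in place of 4-cyanophenyl on a saturated chain carbon bound to an oxygen on an aromatic ring gives a 2.0-fold lower number from compound 3 to compound 4 (0.31 log units; beyond the scatter) in this assay. Going by these compounds alone, this is the first step read at this place, and it shows that the group carried there can move the number beyond the scatter, though only modestly, towards a stronger inhibitor. Nothing at hand says what lies behind this step.

On these data alone, it remains open whether a simpler thiazol-2-yl or an unsubstituted phenyl at the same place would give a number closer to compound 3 or to compound 4. As far as these compounds go, it is also open whether 1,3-benzothiazol-2-yl would have a similar effect alongside the chloro-bearing aryl group of compound 1 on the shared core.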